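Methylsulfanyl in Place of Fluoro: Expected Clearance

The source may hold more compounds than are shown below. What is called first, only, known or untested is meant among the compounds shown, and "the series" means these compounds.

Compound 1 `CNC[C@]1(O)Cc2ccccc2[C@@H]1Oc1ccccc1F`: <= 3 mL/min/kg
Compound 2 `CNC[C@]1(O)Cc2ccccc2[C@@H]1Oc1ccc(O)cc1C`: 10 mL/min/kg
Compound 3 `CNC[C@]1(O)Cc2ccccc2[C@@H]1Oc1cccc(F)c1C`: <= 3 mL/min/kg

In an in vitro ADME assay on microsomes from liver (Rattus norvegicus) for metabolic stability (a higher number here means faster removal of the compound, a lower number slower removal), compound 1 gives <= 3 mL/min/kg, which is a limit of the assay rather than a number. It stands at the limit of <= 3 mL/min/kg in this assay, at which 2 of the 3 values shown sit. Compound 3 shares that limit. Compound 2 gives 10 mL/min/kg.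

The unmeasured compound 4 `CNC[C@]1(O)Cc2ccccc2[C@@H]1Oc1ccccc1SC` differs from compound 1 by methylsulfanyl in place of fluoro on an aromatic carbon. Among the compounds with values here, since no step between two measured compounds is available, the size of this change can only be guessed. The step of an at least 4.0-fold higher number from compound 1 to compound 4 (0.60 log units; beyond the scatter) is expected to run toward faster removal, beyond the usual scatter. Compound 4 is therefore estimated at 12 mL/min/kg, within a range from 4 mL/min/kg to 35 mL/min/kg.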

Compound 4, clearance: 43 mL/min/kg
For compound 4 the middle estimate is 3.6-fold (0.55 log units) below the measured one; measured number above the stated range.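

In this assay, methylsulfanyl in place of fluoro on this aromatic carbon, ortho to a large group, gives an at least 14-fold higher number from compound 1 to compound 4 (1.15 log units; beyond the scatter). Within the data shown here, this is the first single change that can be read in this set, and it shows that the group at this position can move the compound clearly toward faster removal. The step is only a lower bound on the true change, because compound 1 stands at a limit of the assay: the limit of <= 3 mL/min/kg in this assay, at which 2 of the 4 values shown sit.

From the compounds shown here alone, it remains open whether the sulfur atom or simply the extra atom goes with faster removal. Methoxy, chloro or a longer chain such as ethylsulfanyl at this position could separate the two.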